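The compounds below may be only part of what the source reports. "The series", "measured", "known", "first", "only" and "open" are said of these compounds alone.

Of the compounds shown here, three that share one core have been tested in a functional assay on MDA-MB-231 cells (Homo sapiens) for antiproliferative activity, read by MTT assay, with a stated time of 48 h; a higher number here means a weaker inhibitor, a lower number a stronger inhibitor. Compound 3 `CS(=O)(=O)c1ccc(Nc2nccc(Nc3nc4ccc(F)cc4s3)n2)cc1` gives 2080 nM, the lowest of the three numbers. Compound 1 `Cc1cnc(Nc2ccc(S(C)(=O)=O)cc2)nc1Nc1nc2ccc(Cl)cc2s1` gives 5900 nM, and compound 2 `Cc1cnc(Nc2ccc(S(C)(=O)=O)cc2)nc1Nc1nc2ccccc2s1` gives 14800 nM. Among the compounds with values here, the only measured step between compounds differing in a single place, a 2.5-fold higher number from compound 1 to compound 2 (0.40 log units; beyond the scatter), is a modest weakening when the chloro is removed.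

Compound 4 `Cc1cnc(Nc2ccc(S(C)(=O)=O)cc2)nc1Nc1nc2ccc(F)cc2s1` differs from compound 3 by methyl in place of hydrogen on an aromatic carbon. No measured pair isolates this change: compound 1 and compound 2 both already carry the methyl, and compound 3 does not, so the methyl's own effect is not shown. Compound 4 does, however, carry the same fluoro as compound 3 and the same methyl as compound 1 and compound 2, whose numbers are both higher than that of compound 3. On that basis a modest rise, a 2.9-fold higher number from compound 3 to compound 4 (0.46 log units; beyond the scatter), is expected, with considerable uncertainty. The estimate for compound 4 in this assay is 6000 nM, between 2000 nM and 18000 nM.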

Compound 4, half-maximal inhibitory concentration: > 50000 nM
Compound 4: only a limit was reported; the forecaster's own chance of this, stated with the estimate: 5%; middle value at least 8.3-fold (0.92 log units) away from the limit.
By their numbers in this assay, from the lowest: compound 3; then compound 1; then compound 2. At a limit, above all of these: compound 4.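

The number for compound 4 in this assay is a limit and not a measured value: the limit of > 50000 nM in this assay, at which 1 of the 4 values shown sits. Even so, a pair now isolates the methyl on this aromatic carbon, ortho to a large group, and this single added carbon gives an at least 24-fold higher number from compound 3 to compound 4 (1.38 log units; beyond the scatter), a large loss of activity. With the methyl present, the halogen matters too: fluoro in place of hydrogen gives an at least 3.3-fold higher number from compound 2 to compound 4 (0.52 log units; beyond the scatter) and fluoro in place of chloro gives an at least 8.4-fold higher number from compound 1 to compound 4 (0.92 log units; beyond the scatter), so the fluoro moves the number the opposite way from the chloro, whose removal raised it.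

Within the data shown here, the only compound without the methyl carries the fluoro, and whether the methyl costs as much alongside a chloro or a hydrogen stays open. As far as these compounds go, how an ethyl, a methoxy or an amine at this place would compare also stays open.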